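The compounds below may be only part of what the source reports. "The series", "measured", "known", "first", "only" and "open" are said of these compounds alone.

Compound 1 `CN(C)CC[C@H](CSc1ccccc1)Nc1ccc(S(=O)(=O)NC(=O)c2ccc(N3CCN(Cc4ccccc4-c4ccc(Cl)cc4)CC3)cc2)cc1C(F)(F)F`: 3690 ng.h/mL
Compound 2 `CN(C)CC[C@H](CSc1ccccc1)Nc1ccc(S(=O)(=O)NC(=O)c2ccc(N3CCN(Cc4ccccc4-c4ccc(Cl)cc4)CC3)cc2)cc1S(=O)(=O)C(F)(F)F`: 747 ng.h/mL
Compound 3 `CN(C)CC[C@H](CSc1ccccc1)Nc1ccc(S(=O)(=O)NC(=O)c2ccc(N3CCN(Cc4ccccc4-c4ccc(Cl)cc4)CC3)cc2)cc1OC(F)(F)F`: "not determined" (no result reported)

In an ADME assay on the whole organism (plasma, strain Sprague-Dawley) for pharmacokinetics, with Rattus norvegicus as the target, at a dose of 5 mg/kg by the oral route (on this read-out lower numbers stand for lower exposure and higher numbers for higher exposure at the dose given), compound 3 gives "not determined" (no result reported), so it offers no starting value for the next step. Compound 4 `CN(C)CC[C@H](CSc1ccccc1)Nc1ccc(S(=O)(=O)NC(=O)c2ccc(N3CCN(Cc4ccccc4-c4ccc(Cl)cc4)CC3)cc2)cc1C#N` differs from it as follows: cyano in place of trifluoromethoxy on an aromatic carbon. In words, cyano takes the place of trifluoromethoxy on an aromatic carbon.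

Within the data shown here, only one measured step bears on this change. The step of a 4.9-fold lower number from compound 1 to compound 2 (0.69 log units; beyond the scatter) is modest but beyond the usual scatter, and it comes from placing (trifluoromethyl)sulfonyl where trifluoromethyl stood. It shows that a swap on this carbon can shift this assay, but it involves neither cyano nor trifluoromethoxy. With no value for compound 3, no step size or direction can be expected from it. The expectation therefore rests on the shared core, with compound 1 at 3690 ng.h/mL and compound 2 at 747 ng.h/mL as the only anchors, and it falls near the middle of those values. The expected value for compound 4 is 1600 ng.h/mL, with an estimated range of 450 ng.h/mL to 5000 ng.h/mL.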

Compound 4, area under the concentration-time curve: 1740 ng.h/mL
Estimate against measurement, compound 4: 1.1-fold (0.04 log units) below; the measured number falls inside the stated range.
By their numbers in this assay, from the lowest: compound 2; then compound 4; then compound 1.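

In this assay the nitrile gives a third exposure level on this aromatic carbon: cyano in place of (trifluoromethyl)sulfonyl gives a 2.3-fold higher number from compound 2 to compound 4 (0.37 log units; beyond the scatter) and cyano in place of trifluoromethyl gives a 2.1-fold lower number from compound 1 to compound 4 (0.33 log units; beyond the scatter), both modest but beyond the usual scatter. Exposure among these three compounds therefore falls into three separate levels, with compound 4 in the middle, so the earlier drop is no longer the only change seen at this position. Why the groups rank this way stays unexplained, as no supporting measurement bears on the result. Compound 3 has no reported number, so the change from trifluoromethoxy to cyano cannot be read. The compounds shown also leave open how an amine, a carboxylic acid or a plain methyl on this carbon would compare with these three levels.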